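Cytotoxicity of Imine Analogues: Toward a Hydroxyphenyl Variant

The source may hold more compounds than are shown below. What is called first, only, known or untested is meant among the compounds shown, and "the series" means these compounds.

Two compounds of this series have been examined in an ADME assay on HepG2 cells (Homo sapiens) for cytotoxicity, read by MTT assay, with a stated time of 72 h; on this read-out higher numbers stand for lower toxicity in this test and lower numbers for higher toxicity in this test. Compound 1 `Fc1ccc(/C=N/c2sc3c(c2-c2nc4ccccc4s2)CCCC3)cc1` gives 324 ug/mL in this assay. Compound 2 `FC(F)(F)c1ccc(/C=N/c2sc3c(c2-c2nc4ccccc4s2)CCCC3)cc1` gives 361 ug/mL. Going by the values given here, the only measured step, a 1.1-fold higher number from compound 1 to compound 2 (0.05 log units; within the scatter), is small. Among the compounds with values here, compound 2 thus holds the highest of the two numbers so far, but its nearest neighbour, compound 1, sits within the scatter of it, so no order between them can be claimed.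

Compound 3 `Oc1ccccc1/C=N/c1sc2c(c1-c1nc3ccccc3s1)CCCC2` has not yet been measured. It differs from compound 2 in a single place: 2-hydroxyphenyl in place of 4-(trifluoromethyl)phenyl on a carbon with a double bond to nitrogen. Within the data shown here, no measured step in this assay touches a hydroxyl group or a change at this position of the ring attached to the imine carbon; the one step on record, from compound 1 to compound 2, swapped one substituent for another on the same ring and stayed within the scatter. On that basis the expected step of a 1.1-fold lower number from compound 2 to compound 3 (0.04 log units; within the scatter) is judged to be none beyond the scatter. Compound 3 is therefore estimated to give 330 ug/mL in this assay, with a range from 150 ug/mL to 700 ug/mL.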

Compound 3, half-maximal cytotoxic concentration: 114 ug/mL
Compound 3: the middle estimate sits 2.9-fold (0.46 log units) above what was measured; measured number below the stated range.
By their numbers in this assay, from the lowest: compound 3; then compounds 1 and 2 (each within the scatter of the next).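

In this assay, the group on the carbon with a double bond to nitrogen turns out to be able to shift the number beyond the scatter: 2-hydroxyphenyl gives a 3.2-fold lower number from compound 2 to compound 3 (0.50 log units; beyond the scatter) and a 2.8-fold lower number from compound 1 to compound 3 (0.45 log units; beyond the scatter), while the earlier exchange of fluoro for trifluoromethyl on the phenyl ring had shown no such shift. Compound 3 is thus the only one of the three that separates from the others, and the direction of its steps is towards higher toxicity, so this place on the shared core is not indifferent to what is attached there. Nothing at hand bears on why the number falls with this change.

The compounds shown leave open whether the fall goes with the hydroxyl group itself or with its place on the phenyl ring, as compound 3 is the only one that carries it. They also leave open how a methoxy group, an amine or a carboxylic acid on that phenyl ring would read in this assay, and whether any of these would stay with compound 1 and compound 2 or fall with compound 3.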